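Replacing the diisopropylamino group of compound 3

The source may report more compounds than this note shows. Statements on the series, on what has been measured and on what is new or still open speak of the compounds shown alone.

Measured in a functional assay on SK-BR-3 cells (Homo sapiens) for antiproliferative activity; on this read-out higher numbers stand for weaker inhibition and lower numbers for stronger inhibition:
- compound 1 `CC(C)=CCc1cc(C(=O)Nc2cc3ccc(OCC4CCN(C)C4)c(C)c3oc2=O)ccc1O`: 920 nM
- compound 2 `CC(C)=CCc1cc(C(=O)Nc2cc3ccc(OCCCN4CCCC4)c(C)c3oc2=O)ccc1O`: 720 nM
- compound 3 `CC(C)=CCc1cc(C(=O)Nc2cc3ccc(OCCCN(C(C)C)C(C)C)c(C)c3oc2=O)ccc1O`: 1600 nM

Among the compounds with values here, compound 3 stands apart from only one neighbour. a 2.2-fold higher number from compound 2 to compound 3 (0.35 log units; beyond the scatter) is a modest step, while a 1.7-fold higher number from compound 1 to compound 3 (0.24 log units; within the scatter) remains within the scatter. Compound 4 `CC(C)=CCc1cc(C(=O)Nc2cc3ccc(OCCCNCC(N)=O)c(C)c3oc2=O)ccc1O` differs from compound 3 at the end of the chain: (carbamoylmethyl)amino in place of diisopropylamino on a saturated chain carbon, three bonds along the chain from an oxygen on an aromatic ring. Within the data shown here, the step of a 2.2-fold higher number from compound 2 to compound 3 (0.35 log units; beyond the scatter) changes the same place, and a 1.3-fold lower number from compound 1 to compound 2 (0.11 log units; within the scatter) is also small, but no measured compound carries a (carbamoylmethyl)amino group. On these small steps, no change beyond the scatter is expected, although the uncertainty is wide. The expected step is a 1.1-fold lower number from compound 3 to compound 4 (0.06 log units; within the scatter) and no more than that. For compound 4 the estimate is 1400 nM, with an expected range from 600 nM to 3500 nM in this read-out.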

Compound 4, half-maximal inhibitory concentration: 2290 nM
Beside the measured number, compound 4's estimate is 1.6-fold (0.21 log units) below it; the range from low to high includes it.
By their numbers in this assay, from the lowest: compounds 2, 1, 3 and 4 (each within the scatter of the next, the first and the last beyond it).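

In this assay, the step to (carbamoylmethyl)amino at the end of the chain gives a 1.4-fold higher number from compound 3 to compound 4 (0.16 log units; within the scatter) and so cannot be told apart from diisopropylamino. The same group loses ground against the ring-bearing amines, with a 3.2-fold higher number from compound 2 to compound 4 (0.50 log units; beyond the scatter) and a 2.5-fold higher number from compound 1 to compound 4 (0.40 log units; beyond the scatter) as modest steps. Nothing available explains these differences.

On these data alone, whether a carboxylic acid in place of the terminal amide would stay in this range remains open, as does the effect of a longer chain carrying pyrrolidin-1-yl.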